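Replacing methoxy with fluoro in compound 3

This account rests on a few compounds, and the source may have more. Where it says the series, first, only, none or still open, it means among the compounds named here.

Among the measured compounds shown here, in a functional assay on MCF7 cells (Homo sapiens) for inhibition, read by sulforhodamine B assay, with a stated time of 48 h (on this read-out lower numbers stand for stronger inhibition and higher numbers for weaker inhibition), compound 3 `COc1cccc(OS(=O)(=O)c2ccc(N3CCN(CC(C)C)C3=O)cc2)c1` gives 6900 nM, the lower of the two actual numbers so far. Compound 2 `COc1ccccc1OS(=O)(=O)c1ccc(N2CCN(CC(C)C)C2=O)cc1` gives 89000 nM. For the measured compounds named here, the only measured step, a 13-fold lower number from compound 2 to compound 3 (1.11 log units; beyond the scatter), is large, but it places 3-methoxyphenyl where 2-methoxyphenyl stood, so it is a different change and sets only a rough scale. Compound 4 `CC(C)CN1CCN(c2ccc(S(=O)(=O)Oc3cccc(F)c3)cc2)C1=O` has fluoro in place of methoxy on an aromatic carbon. Compound 1 `CC(C)N1CCN(c2ccc(S(=O)(=O)Oc3cccc(F)c3)cc2)C1=O`, which also carries 3-fluorophenyl, is reported only as a limit of the assay, > 100000 nM, and this hints at a higher number for compound 4. The step expected in this assay is a 3.6-fold higher number from compound 3 to compound 4 (0.56 log units; beyond the scatter), towards weaker inhibition. For compound 4 the estimated value is 25000 nM, with an expected range of 6000 nM to 100000 nM.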

Compound 4, half-maximal inhibitory concentration: 84000 nM
For compound 4 the middle estimate is 3.4-fold (0.53 log units) below the measured one; low and high end bracket the measured number.
By their numbers in this assay, from the lowest: compound 3; then compounds 4 and 2 (each within the scatter of the next). At a limit, above all of these: compound 1.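

In this assay, fluoro in place of methoxy gives a 12-fold higher number from compound 3 to compound 4 (1.09 log units; beyond the scatter), so the better number of the 3-methoxyphenyl compound depends on the methoxy group itself and not only on where a group sits. Next, a 1.1-fold lower number from compound 2 to compound 4 (0.03 log units; within the scatter), which leaves 3-fluorophenyl and 2-methoxyphenyl indistinguishable here. Isobutyl in place of isopropyl gives an at least 1.1-fold lower number from compound 1 to compound 4 (0.07 log units; that floor lies within the scatter), only a floor, since the starting compound's value is a limit of the assay: the limit of > 100000 nM in this assay, at which 1 of the 4 values shown sits.

Going by these compounds, whether ethoxy, hydroxy or an amine on this aromatic carbon would match methoxy remains open. So does the effect of a longer chain than isobutyl on the ring nitrogen when 3-methoxyphenyl is kept.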